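Growth of U-251 cells: from methyl to nitro

The compounds below may be only part of what the source reports. "The series", "measured", "known", "first", "only" and "open" are said of these compounds alone.

Measured in a functional assay on U-251 cells (Homo sapiens) for inhibition, read by sulforhodamine B assay, with a stated time of 48 h; on this read-out higher numbers stand for weaker inhibition of growth and lower numbers for stronger inhibition of growth:
- Compound 1 `CCOC(=O)c1nn(-c2ccccc2)c(-c2ccc([N+](=O)[O-])cc2)c1CNC(C)(C)C`: 220000 nM; > 545000 nM (2 entries) (several entries)
- Compound 2 `CC(C)(C)NCc1c(C(=O)O)nn(-c2ccccc2)c1-c1ccc(F)cc1`: > 680000 nM (a limit)
- Compound 3 `Cc1ccc(-c2c(CNC(C)(C)C)c(C(=O)O)nn2-c2ccccc2)cc1`: > 688000 nM (a limit)

Compound 3 has no exact number on this read-out, only the limit > 688000 nM. The next compound to be tested is compound 4 `CC(C)(C)NCc1c(C(=O)O)nn(-c2ccccc2)c1-c1ccc([N+](=O)[O-])cc1`, which has nitro in place of methyl on an aromatic carbon, para to a large group, so that 4-methylphenyl becomes 4-nitrophenyl: nitro in place of methyl on an aromatic carbon.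

Among the measured compounds shown here, only one measured step changes a group at this place. It is a step that the two limits leave unreadable from compound 2 to compound 3, with methyl in place of fluoro on an aromatic carbon, and it gives no size to build on. Compound 1 also carries 4-nitrophenyl but differs from compound 4 elsewhere in the structure. For the measured compounds named here, the record for it is the several entries of compound 1 in this assay, 220000 nM; > 545000 nM (2 entries), so its one exact number sits among limits.

Neither a size nor a direction can therefore be drawn from these data, and no clear shift is expected in this assay. The estimated change is an at least 1.1-fold lower number from compound 3 to compound 4 (0.05 log units; that floor lies within the scatter). Compound 4 is expected at about 600000 nM, with an estimated range from 200000 nM to 1000000 nM.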

Compound 4, concentration for 50% growth inhibition: > 634000 nM
Compound 4 ended at the assay's limit; the forecaster's own chance of this, stated with the estimate: 75%; middle value at least 1.0-fold (0.02 log units) away from the limit.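

Among the compounds shown here, compound 2, compound 3 and compound 4 each stand only as a limit in this assay, so no step among them can be read, in size or in direction. The compounds shown leave open whether fluoro, methyl and nitro at this place differ at all in their inhibition of growth.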